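Two Hydroxyls for Two Methoxys: What to Expect of Compound 4

The compounds below may be only part of what the source reports. "The series", "measured", "known", "first", "only" and "open" are said of these compounds alone.

Compound 1 `O=C(Nc1ccc(F)cc1)N1CCN(S(=O)(=O)c2sccc2-c2ccccc2Oc2ccc(O)c(O)c2)CC1` gives 14800 nM in a functional assay on HeLa cells (Homo sapiens) for inhibition, read by CCK-8 assay, with a stated time of 48 h; on this read-out lower numbers stand for stronger inhibition and higher numbers for weaker inhibition.
Compound 2 `COc1ccc(Oc2ccccc2-c2ccsc2S(=O)(=O)N2CCN(C(=S)Nc3cc(C(F)(F)F)cc(C(F)(F)F)c3)CC2)cc1OC` reaches only a limit in this assay, reported as > 50000 nM.
Compound 3 `COc1ccc(Oc2ccccc2-c2ccsc2S(=O)(=O)N2CCN(C(=O)Nc3ccc(F)cc3)CC2)cc1OC` likewise reaches only a limit in this assay, reported as > 20000 nM.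

Compound 3 and compound 1 differ in a single place: 3,4-dihydroxyphenyl in place of 3,4-dimethoxyphenyl on an oxygen on an aromatic ring This change brought an at least 1.3-fold lower number from compound 3 to compound 1 (0.13 log units; that floor lies within the scatter), and because the limit of > 20000 nM in this assay, at which 1 of the 3 values shown sits, is all that is known of compound 3, only a floor for the size of this step can be given, and that floor lies within the usual scatter of the measurement.

Compound 4 `O=S(=O)(c1sccc1-c1ccccc1Oc1ccc(O)c(O)c1)N1CCN(C(=S)Nc2cc(C(F)(F)F)cc(C(F)(F)F)c2)CC1` has not yet been measured. It stands to compound 2 as compound 1 stands to compound 3: 3,4-dihydroxyphenyl in place of 3,4-dimethoxyphenyl on an oxygen on an aromatic ring The two places are described in the same words, so the change is the same one. How the core of compound 2 differs from the core of compound 3 is not broken down here. For compound 2 itself only a limit is known, (the limit of > 50000 nM in this assay, at which 1 of the 3 values shown sits), so any step to compound 4 starts from that limit rather than from a number.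

Compound 4 is expected to make an at least 1.4-fold lower number from compound 2 to compound 4 (0.15 log units; that floor lies within the scatter) in this assay, a step of similar, modest size, because the same change gave an at least 1.3-fold lower number from compound 3 to compound 1 (0.13 log units; that floor lies within the scatter) on the measured pair. Compound 4 is therefore estimated at about 35000 nM, most likely between 8000 nM and 120000 nM, with a real chance that this assay again reports only a limit.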

Compound 4, half-maximal inhibitory concentration: > 20000 nM
Compound 4 gave a limit, no number (the forecaster's own chance of this, stated with the estimate: 50%); the middle value does not contradict the limit.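

In this assay compound 4 reaches only a limit, > 20000 nM. Among these compounds, compound 2 also reaches only a limit, > 50000 nM, and with a limit on both sides, no step between compound 2 and compound 4 can be read. The compounds shown leave open whether 3,4-dihydroxyphenyl in place of 3,4-dimethoxyphenyl changes inhibition at all, as the only other such pair, compound 3 and compound 1, also rests on a limit.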